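A Solubility Step from Acetoxy to Propanoylamino

The source may hold more compounds than are shown below. What is called first, only, known or untested is meant among the compounds shown, and "the series" means these compounds.

Compound 1 `CN(CCC#N)C[C@H]1CN(c2ccc(-n3cc(-c4ccccn4)cn3)c(F)c2)C(=O)O1` gives 64500 nM in a physicochemical assay for solubility, read by HPLC, with a stated time of 24 h; a lower number here means a less soluble compound, a higher number a more soluble compound.
Compound 2 `O=C1O[C@@H](CN2CCC(O)CC2)CN1c1ccc(-n2cc(-c3ccccn3)cn2)c(F)c1` gives 45900 nM in this assay.
Compound 3 `CC(=O)OC[C@H]1CN(c2ccc(-n3cc(-c4ccccn4)cn3)c(F)c2)C(=O)O1` gives 373000 nM in this assay.

Compound 3 stands highest of the three in this assay. The two steps that reach it are a 5.8-fold higher number from compound 1 to compound 3 (0.76 log units; beyond the scatter) and an 8.1-fold higher number from compound 2 to compound 3 (0.91 log units; beyond the scatter), both beyond the scatter, whereas a 1.4-fold lower number from compound 1 to compound 2 (0.15 log units; within the scatter). Compound 4 `CCC(=O)NC[C@H]1CN(c2ccc(-n3cc(-c4ccccn4)cn3)c(F)c2)C(=O)O1` differs from compound 3 in a single place: propanoylamino in place of acetoxy on a saturated chain carbon bound to a saturated ring carbon. Among the compounds with values here, no measured step bears directly on this exchange. The two steps that end at compound 3 swap acetoxy against (2-cyanoethyl)(methyl)amino or 4-hydroxypiperidin-1-yl, and both were modest in size; here acetoxy gives way to propanoylamino, a group of about the same count with no net charge, so the measured steps offer no direct guide to the direction. The expectation is therefore a step of a 1.5-fold lower number from compound 3 to compound 4 (0.17 log units; within the scatter) in this assay, no change beyond the scatter, with compound 4 estimated at 250000 nM and a range from 80000 nM to 600000 nM.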

Compound 4, solubility: 147000 nM
Beside the measured number, compound 4's estimate is 1.7-fold (0.23 log units) above it, and the stated range covers the measured number.
By their numbers in this assay, from the lowest: compounds 2 and 1 (each within the scatter of the next); then compound 4; then compound 3.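

At this saturated chain carbon bound to a saturated ring carbon, an exchange between two groups with no net charge still moves the number in this assay: a 2.5-fold lower number from compound 3 to compound 4 (0.40 log units; beyond the scatter) shows that acetoxy and propanoylamino are not interchangeable here. Within the data shown here, the amide does not, however, fall back to the level of the two amino-linked compounds, with a 3.2-fold higher number from compound 2 to compound 4 (0.51 log units; beyond the scatter) against 4-hydroxypiperidin-1-yl and a 2.3-fold higher number from compound 1 to compound 4 (0.36 log units; beyond the scatter) against (2-cyanoethyl)(methyl)amino, so this position now shows an intermediate level that the earlier compounds did not. Nothing available explains this ordering of the four compounds.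

The exchange changes two things at once, bringing in the amide hydrogen and lengthening the chain, and these compounds cannot separate one from the other. Acetylamino or propanoyloxy at the same place would each alter only one of these features, while a carboxylic acid or a primary amine on the same chain carbon would show how far the number at this position can move with groups of another kind.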